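The source may hold more compounds than are shown below. What is called first, only, known or untested is meant among the compounds shown, and "the series" means these compounds.

Compound 3 `COc1ccccc1-c1ccc([C@H]2S[C@@H](C)C(=O)Nc3c2c(C)nn3-c2ccccc2C)cc1` stands second highest of the three compounds measured in an assay on isolated protein for agonist activity at Bile acid receptor (Homo sapiens), read by AlphaScreen, with a stated time of 30 min (a higher number here means a larger maximal response, a lower number a smaller maximal response), where compound 3 gives 50%. Its nearest neighbour is compound 1 `Cc1ccccc1-n1nc(C)c2c1NC(=O)[C@H](C)S[C@@H]2c1ccc(-c2ccoc2)cc1`, which in this assay gives 40%; the only measured step that joins two of these compounds is a number 10 percentage points higher from compound 1 to compound 3 (within the scatter). Far away stands compound 2 `CCCc1ccccc1-n1nc(C)c2c1NC(=O)[C@H](C)S[C@@H]2c1ccc(Oc2ccccc2)cc1`, which in this assay gives 240%.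

Compound 4 `Cc1ccccc1-n1nc(C)c2c1NC(=O)[C@H](C)S[C@@H]2c1ccc(Oc2ccccc2)cc1` arises from compound 3 by the change (phenoxy in place of 2-methoxyphenyl on an aromatic carbon). For the measured compounds named here, no measured step bears on this change: the single step known, between compound 1 and compound 3, concerns the exchange of furan-3-yl for 2-methoxyphenyl and not phenoxy. Going by the values given here, compound 2 also carries phenoxy, yet it differs from compound 4 in a second place as well, so its number shows only that a phenoxy-bearing compound can reach a high value. Compound 4 is therefore expected to give 120%, in the range 45% to 240%. The expected step is a number 70 percentage points higher from compound 3 to compound 4 (beyond the scatter), upward but with wide uncertainty.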

Compound 4, largest response reached (reported as efficacy), in percent of the reference or control that the assay uses: 118%
Estimate against measurement, compound 4: 2 percentage points above; the measured number falls inside the stated range.
By their numbers in this assay, from the lowest: compounds 1 and 3 (each within the scatter of the next); then compound 4; then compound 2.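

In this assay, for the compounds shown here, the change at this place, on an aromatic carbon para to a large group, now has a clear size: phenoxy in place of 2-methoxyphenyl gives a number 68 percentage points higher from compound 3 to compound 4 (beyond the scatter) and phenoxy in place of furan-3-yl gives a number 78 percentage points higher from compound 1 to compound 4 (beyond the scatter) where the only earlier step at this place gave no separation. With phenoxy held constant, hydrogen in place of ethyl on the saturated chain carbon gives a number 122 percentage points lower from compound 2 to compound 4 (beyond the scatter) and so shows that the high number of compound 2 does not go with phenoxy alone. Nothing measured here accounts for either step.

Going by these compounds, whether an amine or a carboxylic acid on the phenoxy ring would keep this gain remains open. So does whether a longer chain in place of the ethyl would raise the maximal response further.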